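Removing one methoxy from the benzylamine arm of compound 2

The source may report more compounds than this note shows. Statements on the series, on what has been measured and on what is new or still open speak of the compounds shown alone.

Compound 2 `COc1ccc(CNc2nc3cc(N)cc(N)c3nc2-c2ccccc2)cc1OC` stands in a functional assay on DU-145 cells (Homo sapiens) for inhibition, read by sulforhodamine B assay, with a stated time of 48 h (a higher number here means that more compound is tolerated, a lower number that less compound is tolerated), only at a limit: compound 2 gives < 100000 nM. Compound 1 `Nc1cc(N)c2nc(-c3ccccc3)c(Oc3ccc(Cl)c(Cl)c3)nc2c1` is likewise known only as a limit, < 100000 nM. Compound 3 `COc1cc(CNc2nc3cc(N)cc(N)c3nc2-c2ccccc2)cc(OC)c1OC` also sits at a limit, < 50200 nM. Two values share the limit of < 100000 nM in this assay, at which 2 of the 3 values shown sit, and one sits at the limit of < 50200 nM in this assay, at which 1 of the 3 values shown sits, so the step that the two limits leave unreadable from compound 2 to compound 3 cannot be sized. Compound 4 `COc1ccc(CNc2nc3cc(N)cc(N)c3nc2-c2ccccc2)cc1` differs from compound 2 by hydrogen in place of methoxy on an aromatic carbon. For the measured compounds named here, no measured step gives a number for this kind of change, and the single neighbouring step is unreadable, so no direction beyond the scatter can be expected. Compound 4 is expected near 60000 nM, within 15000 nM to 100000 nM, most likely again reported as a limit. The implied step is expected as a step that the limit leaves unreadable from compound 2 to compound 4.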

Compound 4, concentration lethal to 50% of the cells: < 100000 nM
Compound 4 ended at the assay's limit; the forecaster's own chance of this, stated with the estimate: 70%; the middle value does not contradict the limit.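

For the compounds shown here, compound 2 and compound 4 are both known only as limits, so no step between them can be read. The compounds shown leave open whether the change from 3,4-dimethoxyphenyl to 4-methoxyphenyl shifts the read-out at all.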